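This account rests on a few compounds, and the source may have more. Where it says the series, first, only, none or still open, it means among the compounds named here.

Measured so far:
- compound 1, `CNC(=O)c1c(O)c2cccnc2n(-c2ccccc2)c1=O`: 21%
- compound 2, `O=C(Nc1cccc([N+](=O)[O-])c1)c1c(O)c2cccnc2n(-c2ccccc2)c1=O`: 7.4%

In a functional assay on the whole organism for inhibition, with Rattus norvegicus as the target, read by cytopathic effect and paw edema, at a dose of 100 mg/kg by the oral route (on this read-out lower numbers stand for less inhibition and higher numbers for more inhibition at the one dose given (going by the name of the read-out)), compound 2 gives 7.4%, the lower of the two numbers recorded; the nearest is compound 1 with 21%, and the gap from compound 1 to compound 2 lies beyond the scatter. Among the compounds with values here, the one measured step, a number 13.6 percentage points lower from compound 1 to compound 2 (beyond the scatter), is the replacement of methyl by 3-nitrophenyl on the amide-type nitrogen.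

Compound 3, `O=C(Nc1cnccn1)c1c(O)c2cccnc2n(-c2ccccc2)c1=O`, is not yet measured. It differs from compound 2 in one place: pyrazin-2-yl in place of 3-nitrophenyl on an amide-type nitrogen. Within the data shown here, this is an exchange of one aromatic group for another on the same amide-type nitrogen, whereas the measured step went from methyl to an aromatic group, so no measured step speaks to this change directly. Among the measured compounds shown here, both compound 2 and compound 3 carry an aromatic group on that nitrogen, and the sole measured step gives no indication that one aromatic group should differ from another beyond the scatter. Compound 3 is therefore expected to sit near compound 2, the expected step being a number 2.6 percentage points higher from compound 2 to compound 3 (within the scatter), with no clear direction. The estimate for compound 3 is 10%, within a range of 0% to 30%.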

Compound 3, a percentage reported as inhibition, in the whole organism at one dose (the size of the read-out at that dose, not a potency): 21.2%
Compound 3: the middle estimate sits 11.2 percentage points below what was measured; measured number inside the range.
By their numbers in this assay, from the lowest: compound 2; then compounds 1 and 3 (each within the scatter of the next).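

In this assay, pyrazin-2-yl in place of 3-nitrophenyl on the amide-type nitrogen gives a number 13.8 percentage points higher from compound 2 to compound 3 (beyond the scatter) and so shows that two aromatic groups at this place need not read alike, which the earlier pair could not show. Against methyl, the same pyrazin-2-yl group gives a number 0.2 percentage points higher from compound 1 to compound 3 (within the scatter) so an aromatic ring on this nitrogen does not by itself go with the lower number, and among the three compounds only compound 2, with its 3-nitrophenyl group, stands apart from the other two. Nothing on hand accounts for the gap between the two aromatic groups, so the part played by the nitro group or by the ring nitrogens of pyrazin-2-yl stays unexplained.

Still open, from the compounds shown here alone, is whether an unsubstituted phenyl, a pyridin-2-yl or a 3-aminophenyl group on this nitrogen would read with compound 2 or with compound 3, which would show whether the nitro group marks the difference. Also open, going by these compounds, is how a longer alkyl chain or a chain ending in a carboxylic acid would compare with methyl at this place, and each reading here comes from one dose only.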